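The compounds below may be only part of what the source reports. "The series", "measured", "known", "first", "only" and "open" are said of these compounds alone.

Working notes on the series. In a functional assay on B16 cells (Mus musculus) for antiproliferative activity, read by MTT assay, with a stated time of 24 h (on this read-out lower numbers stand for stronger inhibition and higher numbers for weaker inhibition), compound 1 (`COc1cc(OC)c(-c2coc3cc(OCc4ccc(Br)cc4)ccc3c2=O)cc1OC`) gives 1180 nM. Compound 2 (`COc1cc(OC)c(-c2coc3cc(OCc4ccc([N+](=O)[O-])cc4)ccc3c2=O)cc1OC`) reads > 10000 nM, which is a limit of the assay and not a number. Compound 2 therefore has no measured position in this assay, only this limit.

The next change leads to compound 3 (`COc1cc(OC)c(-c2coc3cc(OCc4ccc(C#N)cc4)ccc3c2=O)cc1OC`): cyano in place of nitro on an aromatic carbon. In words, this is cyano in place of nitro on an aromatic carbon, para to a large group. Among the compounds with values here, one measured step bears on it, at the same place: an at least 8.4-fold higher number from compound 1 to compound 2 (0.92 log units; beyond the scatter), with nitro in place of bromo. Cyano itself has not been measured in this series, so the basis is thin. Removing the nitro group that accompanied an at least 8.4-fold higher number from compound 1 to compound 2 (0.92 log units; beyond the scatter) leads to the expectation of a lower number in this assay, recovering only part of that step and possibly staying at the limit. The expected change is an at least 2.5-fold lower number from compound 2 to compound 3 (0.39 log units; beyond the scatter), an estimate of modest size with wide uncertainty. For compound 3 the expected value is 4000 nM, with an estimated range of 1200 nM to 13000 nM.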

Compound 3, half-maximal inhibitory concentration: 7000 nM
Compound 3: middle estimate off by 1.8-fold (0.24 log units), on the low side; low and high end bracket the measured number.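

In this assay, within the data shown here, the aromatic carbon para to a large group now has a second replacement for bromo that gives a number and not only a limit (a 5.9-fold higher number from compound 1 to compound 3 (0.77 log units; beyond the scatter)), so the size of a loss from bromo can be stated at this place for the first time. Cyano and nitro both go with weaker inhibition than bromo here, which shows that the earlier loss with nitro is not a lone case among the three compounds, though two replacements are too few to call it a pattern. The change from nitro to cyano can be read only as a floor (an at least 1.4-fold lower number from compound 2 to compound 3 (0.15 log units; that floor lies within the scatter)), and no order between these two groups follows from it, since compound 2 sits at a limit of the assay and not at a number: the limit of > 10000 nM in this assay, at which 1 of the 3 values shown sits.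

As far as these compounds go, whether chloro, fluoro or methoxy at this carbon would read close to bromo, and whether an amine or a carboxylic acid would fall further off, stays open. Also open, from the compounds shown here alone, is whether any group here gives a lower number than compound 1, and whether the same order of groups would hold at another carbon of that ring.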